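Sulfonyl aryl swaps on the shared core

This account rests on a few compounds, and the source may have more. Where it says the series, first, only, none or still open, it means among the compounds named here.

Measured so far:
compound 1 `CNC(=O)/C=C1/COc2cc(OS(=O)(=O)c3cccc(C#N)c3)ccc21` — 0%
compound 2 `CNC(=O)/C=C1/COc2cc(OS(=O)(=O)c3ccc([N+](=O)[O-])cc3)ccc21` — 13%

In an assay (strain Sprague-Dawley) for inhibition of Amine oxidase [flavin-containing] B (Rattus norvegicus), read by spectrophotometry, with a stated time of 5 min, tested at 10 uM (on this read-out higher numbers stand for more inhibition at the one concentration tested (going by the name of the read-out) and lower numbers for less inhibition), compound 1 gives 0% and stands lowest of the two numbers measured. Its nearest neighbour is compound 2, reached by a step of a number 13 percentage points higher from compound 1 to compound 2 (beyond the scatter), a modest rise that lies beyond the scatter of this assay.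

Compound 3 `CNC(=O)/C=C1/COc2cc(OS(=O)(=O)c3ccc(OC)cc3)ccc21` differs from compound 1 by 4-methoxyphenyl in place of 3-cyanophenyl on a sulfonyl sulfur. Going by the values given here, the only measured step that bears on it is the one from compound 1 to compound 2, which exchanges the same leaving group at the same sulfonyl sulfur for a different entering group and brings a number 13 percentage points higher from compound 1 to compound 2 (beyond the scatter). Among the compounds with values here, that step was modest; no measured step covers the 4-methoxyphenyl group itself. A small rise or no change beyond the scatter is therefore expected, a number 7 percentage points higher from compound 1 to compound 3 (within the scatter), for compound 3. In this assay compound 3 is estimated at 7%, within 0% to 22%.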

Compound 3, a percentage reported as inhibition, at one concentration (the size of the read-out at that concentration, not a potency): 0%
Compound 3: middle estimate off by 7 percentage points, on the high side; the range from low to high includes it.
By their numbers in this assay, from the lowest: compounds 1 and 3 (each within the scatter of the next); then compound 2.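

On the sulfonyl sulfur, 4-methoxyphenyl in place of 3-cyanophenyl gives no change at the digits printed from compound 1 to compound 3 (within the scatter) in this assay, so this exchange of aryl groups does not separate the two compounds on this read-out. Methoxy in place of nitro on an aromatic carbon gives a number 13 percentage points lower from compound 2 to compound 3 (beyond the scatter), so one exchange on the aryl ring is enough to produce a modest step at this position, and compound 2 is the only one of the three that stands beyond the scatter of the others. Nothing available explains this difference.

Open, on these data alone, is whether an amine or a carboxylic acid on the aryl ring would reach a number beyond that of compound 2. Also open, as far as these compounds go, is whether a saturated alkyl chain on the sulfonyl sulfur, in place of the aryl ring, would retain any inhibition.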